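The source may report more compounds than this note shows. Statements on the series, on what has been measured and on what is new or still open speak of the compounds shown alone.

Going by the values given here, compound 2 `COc1ccc(CNC(=O)/C(C#N)=C/c2ccc(Br)o2)cc1` stands lowest of the two numbers measured so far. In a functional assay on SMA cells (Homo sapiens) for inhibition, read by MTT assay, with a stated time of 72 h (a lower number here means a stronger inhibitor of growth, a higher number a weaker inhibitor of growth), compound 2 gives 14000 nM, and compound 1 `COc1ccc(CNC(=O)/C(C#N)=C/c2ccco2)cc1` gives 33000 nM in this assay. Among the compounds with values here, the one measured step, a 2.4-fold lower number from compound 1 to compound 2 (0.37 log units; beyond the scatter), is modest and is bromo in place of hydrogen on an aromatic carbon. Compound 3 `COc1ccc(CNC(=O)/C(C#N)=C/c2ccc(Cl)cc2)cc1` differs from compound 2 by 4-chlorophenyl in place of 5-bromofuran-2-yl on a double-bonded chain carbon bound to a double-bonded chain carbon. Within the data shown here, no measured pair shows an exchange of one aromatic ring for another, so the measured step bears on this change only loosely: compound 3 keeps a halogen on its aromatic ring but gives up the ring that carried the bromine in compound 2. A small step in either direction, or none beyond the scatter, is expected in this assay. The expected step is a 1.4-fold higher number from compound 2 to compound 3 (0.15 log units; within the scatter). The estimate for compound 3 is 20000 nM, with a range from 6000 nM to 60000 nM.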

Compound 3, concentration for 50% growth inhibition: 17000 nM
Beside the measured number, compound 3's estimate is 1.2-fold (0.07 log units) above it; measured number inside the range.
By their numbers in this assay, from the lowest: compounds 2, 3 and 1 (each within the scatter of the next, the first and the last beyond it).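

At the double-bonded chain carbon, a six-membered aromatic ring of carbon only can take the place of a five-membered one: in this assay there is a 1.2-fold higher number from compound 2 to compound 3 (0.08 log units; within the scatter) and the numbers of the two compounds do not separate 4-chlorophenyl from 5-bromofuran-2-yl. The other new reading, a 1.9-fold lower number from compound 1 to compound 3 (0.29 log units; within the scatter), places 4-chlorophenyl within the scatter of furan-2-yl as well, whereas the bromo step on the furan ring lies beyond it. No data here bear on why these ring exchanges leave the numbers so close.

Still open, from the compounds shown here alone, is what the chlorine itself contributes, which a plain phenyl at this place would show. Also open, going by these compounds, is whether a pyridine ring, or a phenyl ring carrying an amine or a carboxylic acid, stays in this range.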